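The compounds below may be only part of what the source reports. "The series", "measured", "known", "first", "only" and "open" are said of these compounds alone.

Three compounds form the background to this step, and only compound 2 `CN1CCN(c2ccc(Nc3ncc4nc(Nc5ccc(F)cc5)n([C@H]5CCCN(S(=O)(=O)C6CC6)C5)c4n3)cc2)CC1` carries a number. In a functional assay on A-431 cells (Homo sapiens) for antiproliferative activity, read by MTT assay, with a stated time of 72 h (on this read-out higher numbers stand for weaker inhibition and lower numbers for stronger inhibition), compound 2 gives 1340 nM. Compound 1 `CN1CCN(c2ccc(Nc3ncc4nc(Nc5ccccc5)n([C@H]5CCN(S(C)(=O)=O)C5)c4n3)cc2)CC1` has "not determined" (no result reported) in this assay, and compound 3 `CC(=O)Nc1cccc(-n2c(Nc3ccc(F)cc3)nc3cnc(Nc4ccc(N5CCN(C)CC5)cc4)nc32)c1` likewise has "not determined" (no result reported), so compound 2 stands alone, with nothing measured to rank it against. Compound 4 `CN1CCN(c2ccc(Nc3ncc4nc(Nc5ccc(F)cc5)n(-c5cccc(NC(=O)CO)c5)c4n3)cc2)CC1` differs from compound 2 in a single place: 3-(((hydroxymethyl)carbonyl)amino)phenyl in place of 1-(cyclopropylsulfonyl)piperidin-3-yl on an aromatic nitrogen. For the measured compounds named here, no measured pair shows what such a change does in this assay, so the direction is open; a modest shift, not clearly beyond the usual scatter, is expected, namely a 1.5-fold lower number from compound 2 to compound 4 (0.17 log units; within the scatter). On that basis compound 4 is estimated at 900 nM, within a range from 150 nM to 5000 nM.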

Compound 4, half-maximal inhibitory concentration: 1670 nM
Estimate against measurement, compound 4: 1.9-fold (0.27 log units) below; measured number inside the range.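

In this assay, replacing the 1-(cyclopropylsulfonyl)piperidin-3-yl group with 3-(((hydroxymethyl)carbonyl)amino)phenyl on the aromatic nitrogen gives a 1.2-fold higher number from compound 2 to compound 4 (0.10 log units; within the scatter). This position therefore tolerates two quite different groups, one with a non-aromatic ring and one with an aromatic ring, without a change in the read-out that stands beyond the scatter. Nothing available explains this result. From the compounds shown here alone, whether a smaller substituent such as a methyl group on that nitrogen would shift the number remains open. So does the effect of a carboxylic acid or an amine on the phenyl ring.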